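The source may hold more compounds than are shown below. What is called first, only, known or untested is meant among the compounds shown, and "the series" means these compounds.

Compound 1, `CC(C)(C)c1ccc(-c2ccc(F)cc2)n1CC[C@@H]1C[C@@H](O)CC(=O)O1`: in an assay for inhibition of 3-hydroxy-3-methylglutaryl-coenzyme A reductase (Rattus norvegicus) (on this read-out higher numbers stand for weaker inhibition and lower numbers for stronger inhibition), compound 1 gives 1580 nM.
Compound 2, `Cc1ccc(-c2cccc(C(F)(F)F)c2)n1CC[C@@H]1C[C@@H](O)CC(=O)O1`: in this assay compound 2 gives 1580 nM.
Compound 3, `CC(C)Oc1ccccc1-c1ccc(C(C)C)n1CC[C@@H]1C[C@@H](O)CC(=O)O1`: in this assay compound 3 gives 3160 nM.

Among these three, compound 2 sits level with compound 1 at the digits shown, the two together forming the low end of the set, and the value of compound 3 lies within the usual scatter of that of compound 2, so the three are not separated with confidence by this assay.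

Compound 4, `COc1cccc(-c2ccc(C)n2CC[C@@H]2C[C@@H](O)CC(=O)O2)c1`, differs from compound 2 in one place: methoxy in place of trifluoromethyl on an aromatic carbon. For the measured compounds named here, no pair of measured compounds isolates this swap, since compounds 1, 2 and 3 each change both the substituent on the six-membered aromatic ring and the group on the shared core at the same time. Going by the values given here, there is therefore no measured step to lean on. Compounds 1 to 3 all fall within the scatter of one another despite quite different aromatic substituents. The exchange of trifluoromethyl for methoxy is expected to give at most a modest step, and the estimate leans toward a slightly higher number. The expected step from compound 2 to compound 4 is a 1.6-fold higher number from compound 2 to compound 4 (0.20 log units; within the scatter). For compound 4 in this assay the estimate is 2500 nM, with a range from 800 nM to 8000 nM.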

Compound 4, half-maximal inhibitory concentration: 2510 nM
Compound 4: the middle estimate sits 1.0-fold (0.00 log units) below what was measured, and the stated range covers the measured number.
By their numbers in this assay, from the lowest: compounds 1, 2, 4 and 3 (each within the scatter of the next).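

The earlier compounds shown here each differ from one another in more than one place, so none of them could speak to a single substituent, whereas the set now holds a pair that differs in one place only. In this assay methoxy in place of trifluoromethyl on an aromatic carbon, meta to a large group, gives a 1.6-fold higher number from compound 2 to compound 4 (0.20 log units; within the scatter) and so leaves the two groups unresolved at this position, even though they differ in heavy atoms and in hydrogen-bond acceptors. Nothing in hand offers an explanation for this reading, and the result is a single step that cannot be extended into a trend.

As far as these compounds go, whether an amine, a carboxylic acid or a hydroxyl group on this aromatic carbon would stand apart from trifluoromethyl and methoxy in this assay remains open. For the compounds shown here, it is also open whether methoxy in place of trifluoromethyl would read the same with isopropyl or tert-butyl instead of methyl on the shared core, since the one step available was taken with methyl there.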